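Working notes: a fluoro added to compound 1

This account rests on a few compounds, and the source may have more. Where it says the series, first, only, none or still open, it means among the compounds named here.

- compound 1 `C[C@@H]1CN(C(=O)C(=O)Nc2ccc3[nH]c(=O)oc3c2)CCN1c1ccc(Cl)cc1` gives 15.6 mL/min/kg
- compound 2 `C[C@H]1CN(C(=O)C(=O)Nc2ccc3[nH]c(=O)oc3c2)CCN1c1ccc(Cl)cc1` gives "not determined" (no result reported)

For the measured compounds named here, in an ADME assay on the whole organism (Rattus norvegicus, strain Sprague-Dawley) for pharmacokinetics, using cassette dosing, at a dose of 0.5 mg/kg by the intravenous route (on this read-out higher numbers stand for fast clearance and lower numbers for slow clearance), compound 1 gives 15.6 mL/min/kg as the only number available, and it has no measured neighbour to be ranked against. Going by these compounds, compound 2 is its closest relative (the fact that compounds 1 and 2 differ only in the configuration as drawn) but yields no number, and the effect of configuration remains open. The next compound is compound 3 `C[C@@H]1CN(C(=O)C(=O)Nc2ccc3[nH]c(=O)oc3c2)CCN1c1ccc(Cl)c(F)c1` with fluoro in place of hydrogen on an aromatic carbon, ortho to a chloro group (fluoro in place of hydrogen on an aromatic carbon). This takes 4-chlorophenyl to 4-chloro-3-fluorophenyl. Going by the values given here, no measured step covers this change. The expected 1.1-fold lower number from compound 1 to compound 3 (0.05 log units; within the scatter) is small, stays within the usual scatter and has no firm direction. The estimate rests on compound 1 alone at 15.6 mL/min/kg and on nothing else. Compound 3 is expected at 14 mL/min/kg with an estimated range from 7 mL/min/kg to 28 mL/min/kg as the likely span.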

Compound 3, clearance: 6 mL/min/kg
Estimate against measurement, compound 3: 2.3-fold (0.37 log units) above; the whole stated range lies above it.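

In this assay, for the compounds shown here, taking 4-chlorophenyl to 4-chloro-3-fluorophenyl gives a 2.6-fold lower number from compound 1 to compound 3 (0.41 log units; beyond the scatter) and so supplies the first measured step. This aromatic position, ortho to the chloro group, is therefore sensitive in this read-out: a single fluoro in place of hydrogen moves clearance beyond the usual scatter, which compound 1 alone could not show. The data shown offer no measured basis for explaining this step, and it rests on one pair of compounds only.

Going by these compounds, whether a larger or different group at this position, such as a methyl, methoxy or nitrile, would move clearance in the same direction remains open. Compound 2 carries no number, so the role of configuration, with or without the fluoro, also stays unresolved.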